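Capping the carbonyl with dimethylamino on compound 2

The source may report more compounds than this note shows. Statements on the series, on what has been measured and on what is new or still open speak of the compounds shown alone.

Measured in a functional assay on the whole organism for antagonist activity, with Mus musculus as the target (on this read-out higher numbers stand for an effect only at larger amounts of compound and lower numbers for an effect already at smaller amounts), each value a limit and not a number:
- compound 1 `CC(=O)NCC#CCn1ccnc1`: > 100 mg/kg
- compound 2 `CC(=O)N(C)CC#CCn1ccnc1`: > 100 mg/kg
- compound 3 `CC(=O)N(C)CC#CCn1cncc1C`: > 100 mg/kg

In this assay compound 2 gives > 100 mg/kg, which is a limit and not a number. Compound 4 `CN(C)C(=O)N(C)CC#CCn1ccnc1` differs from it in one place: dimethylamino in place of methyl on a carbonyl carbon, or acetyl to dimethylcarbamoyl. Among the measured compounds shown here, two measured steps bear on this, a step that the two limits leave unreadable from compound 1 to compound 2 and a step that the two limits leave unreadable from compound 2 to compound 3, and neither has a readable size or changes the carbonyl carbon. For the measured compounds named here, the only evidence is the limit of > 100 mg/kg in this assay, at which 3 of the 3 values shown sit. No direction can therefore be expected, and the expected step that the limit leaves unreadable from compound 2 to compound 4 is none beyond the scatter. Compound 4 is estimated at 150 mg/kg, with a range of 50 mg/kg to 450 mg/kg, and it may well report only a limit too.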

Compound 4, dose for half-maximal effect: > 100 mg/kg
Compound 4 was reported as a limit (the forecaster's own chance of this, stated with the estimate: 75%); the middle value is on the limit's open side.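

Among the compounds shown here, compound 2 and compound 4 each report only a limit and not a number, and no step between them can be read. The compounds shown leave open the dose at which any of them reaches a half-maximal effect, since all share one limit: the limit of > 100 mg/kg in this assay, at which 4 of the 4 values shown sit.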